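A few compounds are considered here, and "the series" means these few. Any claim that something is new, unique, unknown or untested is made for them only; others in the source may bear on it.

Measured compounds:
compound 1, `COc1ccc(-c2cc(/C=C/C(=O)c3cc(OC)c(OC)c(OC)c3)nc3cc(-c4ccccc4)nn23)cc1OC`, 7200 nM
compound 2, `COc1ccc(C(=O)/C=C/c2cc(-c3ccc(OC)c(OC)c3)n3nc(-c4ccccc4)cc3n2)cc1OC`, 3900 nM

Of the two numbers in a functional assay on A549 cells (Homo sapiens) for antiproliferative activity, read by MTT assay, with a stated time of 24 h (a lower number here means a stronger inhibitor, a higher number a weaker inhibitor), compound 2 holds the lower one, but its nearest neighbour is compound 1, and the step of a 1.8-fold lower number from compound 1 to compound 2 (0.27 log units; within the scatter) lies within the scatter, so the two cannot be ordered. Compound 3, `COc1ccc(-c2cc(/C=C/C(=O)c3ccc(Cl)cc3)nc3cc(-c4ccccc4)nn23)cc1OC`, differs from compound 2 by 4-chlorophenyl in place of 3,4-dimethoxyphenyl on a carbonyl carbon.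

Among the measured compounds shown here, only one measured step touches this part of the molecule: a 1.8-fold lower number from compound 1 to compound 2 (0.27 log units; within the scatter), which altered the same aryl group on the carbonyl carbon and produced no change beyond the scatter. Nothing measured covers the replacement of the whole aryl group, so the expectation rests on that single step alone. The estimate for compound 3 is therefore a step of a 1.2-fold higher number from compound 2 to compound 3 (0.06 log units; within the scatter), not beyond the scatter. Compound 3 is expected to give 4500 nM in this assay, with a range from 1500 nM to 14000 nM.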

Compound 3, half-maximal inhibitory concentration: 15400 nM
Estimate against measurement, compound 3: 3.4-fold (0.53 log units) below, outside the stated range (above it).
By their numbers in this assay, from the lowest: compounds 2 and 1 (each within the scatter of the next); then compound 3.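

In this assay, replacing the whole aryl group on the carbonyl carbon moves the number in a way the earlier change between methoxy-bearing groups did not: 4-chlorophenyl in place of 3,4-dimethoxyphenyl gives a 3.9-fold higher number from compound 2 to compound 3 (0.60 log units; beyond the scatter) and 4-chlorophenyl in place of 3,4,5-trimethoxyphenyl gives a 2.1-fold higher number from compound 1 to compound 3 (0.33 log units; beyond the scatter) and both steps lie beyond the scatter. Among these three compounds, the two methoxy-bearing groups cannot be ordered, while the 4-chlorophenyl group carries the higher number against each of them. Nothing measured here accounts for this difference.

Going by these compounds, whether the higher number goes with the chlorine or with the loss of the methoxy groups stays open. On these data alone, a plain phenyl or a 4-methoxyphenyl group on the same carbonyl carbon would bear on that question, and how a 4-aminophenyl group would read there is equally open.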